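Benzoyl addition to compound 1: expected effect on inhibition

The source may report more compounds than this note shows. Statements on the series, on what has been measured and on what is new or still open speak of the compounds shown alone.

In a functional assay on A549 cells (Homo sapiens) for inhibition (on this read-out higher numbers stand for weaker inhibition and lower numbers for stronger inhibition), compound 1 (`Cc1cccc2cc([C@@H]3[C@@H](C(=O)c4ccccc4)C4(c5ccccc5-c5nc6ccccc6nc54)N4CSC[C@@H]34)c(Cl)nc12`) gives 14000000 nM and compound 2 (`Cc1cc(C)c2nc(Cl)c([C@@H]3[C@@H](C(=O)c4ccccc4)C4(c5ccccc5-c5nc6ccccc6nc54)N4CSC[C@@H]34)cc2c1`) gives 15000000 nM, so the two stand level within the scatter. Compound 3 (`Cc1cccc2cc([C@@H]3[C@@H](C(=O)c4ccccc4)C4(c5ccccc5-c5nc6ccc(C(=O)c7ccccc7)cc6nc54)N4CSC[C@@H]34)c(Cl)nc12`) differs from compound 1 by benzoyl in place of hydrogen on an aromatic carbon, in a six-membered aromatic ring of carbon only, part of a fused or bridged system of six rings. For the measured compounds named here, the sole measured step, a 1.1-fold higher number from compound 1 to compound 2 (0.03 log units; within the scatter), is methyl in place of hydrogen and offers only weak guidance for a benzoyl. No shift beyond the scatter is expected in this assay, and the expected step is a 1.1-fold lower number from compound 1 to compound 3 (0.03 log units; within the scatter). For compound 3 the estimate is 13000000 nM, with an expected range of 4000000 nM to 40000000 nM.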

Compound 3, half-maximal inhibitory concentration: 13000000 nM
Compound 3: middle estimate and measured number agree at the digits printed; the measured number falls inside the stated range.
By their numbers in this assay, from the lowest: compounds 3, 1 and 2 (each within the scatter of the next).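

Benzoyl in place of hydrogen on this aromatic carbon, meta to a fused ring and para to a fused ring, gives a 1.1-fold lower number from compound 1 to compound 3 (0.03 log units; within the scatter) in this assay. The position therefore takes a whole added benzoyl with no shift beyond the scatter, whereas the earlier step concerned only a methyl at another place on the shared core. No available data explain this result. Still open, on these data alone, is whether an amine or a carboxylic acid at this carbon would move the number beyond the scatter.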